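The source may report more compounds than this note shows. Statements on the series, on what has been measured and on what is new or still open speak of the compounds shown alone.

Of the compounds shown here, three sharing one core have been measured in an assay on CHO cells for antagonist activity at transient receptor potential cation channel subfamily V member 1 (Homo sapiens), read by FLIPR (a lower number here means a stronger inhibitor, a higher number a weaker inhibitor), and they differ only in the group on one aromatic carbon. Compound 1 `CC(C(=O)NCc1ccc(C(F)(F)F)cc1N1CCCCCC1)c1ccc(NS(C)(=O)=O)c(F)c1` gives 1.6 nM. Compound 2 `CC(C(=O)NCc1ccc(C(F)(F)F)cc1N1CCN(C2CCCCC2)CC1)c1ccc(NS(C)(=O)=O)c(F)c1` gives 13.8 nM. Compound 3 `CC(C(=O)NCc1ccc(C(F)(F)F)cc1SC1CCCC1)c1ccc(NS(C)(=O)=O)c(F)c1` gives 0.3 nM, the lowest of the three: the step of a 5.3-fold lower number from compound 1 to compound 3 (0.73 log units; beyond the scatter) and the step of a 46-fold lower number from compound 2 to compound 3 (1.66 log units; beyond the scatter) both go down, while the step of an 8.6-fold higher number from compound 1 to compound 2 (0.94 log units; beyond the scatter) goes up.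

Compound 4 `CC(C(=O)NCc1ccc(C(F)(F)F)cc1-c1ccc(C(C)(C)C)cc1)c1ccc(NS(C)(=O)=O)c(F)c1` is not yet measured. It differs from compound 3 in this way: 4-(tert-butyl)phenyl in place of cyclopentylsulfanyl on an aromatic carbon. Every measured step in this assay concerns this same position, so all three bear on the change, but none of them introduces an aromatic group there; each replacement of the cyclopentylsulfanyl group seen so far has given a higher number, by a modest and by a large amount. Because compound 3 stands at 0.3 nM, the lowest number, a modest rise is expected, a 6.7-fold higher number from compound 3 to compound 4 (0.82 log units; beyond the scatter). Compound 4 is therefore estimated at 2 nM, within a range of 0.5 nM to 8 nM.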

Compound 4, inhibition constant: 1.1 nM
Estimate against measurement, compound 4: 1.8-fold (0.26 log units) above, within the range that was stated.
By their numbers in this assay, from the lowest: compound 3; then compounds 4 and 1 (each within the scatter of the next); then compound 2.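

In this assay this position accepts an aromatic ring joined directly by carbon, whereas every earlier group was joined through nitrogen or sulfur, and the rise against the cyclopentylsulfanyl group stays modest (a 3.7-fold higher number from compound 3 to compound 4 (0.56 log units; beyond the scatter)). The 4-(tert-butyl)phenyl group, made of carbon only and with no hydrogen-bond acceptor, gives a far lower number than the 4-cyclohexylpiperazin-1-yl group (a 13-fold lower number from compound 2 to compound 4 (1.10 log units; beyond the scatter)) and cannot be told apart from the azepan-1-yl group (a 1.5-fold lower number from compound 1 to compound 4 (0.16 log units; within the scatter)). Nothing at hand explains why these groups differ.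

The compounds shown leave open what the tert-butyl group itself contributes, and how a plain phenyl, a pyridine or a 4-methoxyphenyl would read here. They also leave open whether a cyclopentyloxy group, with oxygen in place of sulfur, would read like the cyclopentylsulfanyl group.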